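The compounds below may be only part of what the source reports. "The series", "measured", "known", "first", "only" and "open" are said of these compounds alone.

Compound 1 `NN1C(=O)/C(=C/c2ccc(Cl)cc2)SC1=S` is reported in an assay for inhibition of LL-diaminopimelate aminotransferase, chloroplastic (Arabidopsis thaliana) (on this read-out lower numbers stand for stronger inhibition and higher numbers for weaker inhibition), as "not active" (no number reported). Compound 2 `Cc1ccc(NC(=O)/C(C#N)=C/c2ccc(N(C)C)o2)cc1C` reaches only the limit of this assay, > 200000 nM, and that is a limit rather than a measured number. Compound 3 `CCN1C(=O)/C(=C/c2cccc3ccccc23)SC1=S` gives 200000 nM in this assay.

Compound 1 therefore stands without any number of its own; the only limit shown, (the limit of > 200000 nM in this assay, at which 1 of the 3 values shown sits), belongs to compound 2, and the one numerical value in the set, from compound 3, sits at the same concentration as that limit. The three compounds together show no inhibition worth the name.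

Compound 4 `CCN1C(=O)/C(=C/c2ccc(Cl)cc2)SC1=S` has not been measured in this assay. For the measured compounds named here, its one difference from compound 1 is ethyl in place of amino on an amide-type nitrogen in a ring. Going by the values given here, no measured pair in this set shares that change, so no step for it can be drawn. Compound 3 already carries an ethyl on the ring nitrogen and stays at 200000 nM in this assay, which gives no ground to expect more than a step within the scatter, in either direction.

Compound 4 is therefore expected to give about 200000 nM in this assay, with a likely range from 80000 nM to 600000 nM, and a real chance that only a limit is reported.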

Compound 4, half-maximal inhibitory concentration: 200000 nM
Estimate against measurement, compound 4: no gap at the digits printed; low and high end bracket the measured number.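

For the compounds shown here, compound 4 now has a number, but in this assay compound 1 is reported only as "not active" (no number reported), so no step between the two can be read. The compounds shown leave open whether ethyl in place of amino on the amide-type nitrogen in a ring changes inhibition at all.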